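From a 2-chlorophenyl amide to a 4-methylphenyl amide

The compounds below may be only part of what the source reports. "The series", "measured", "known", "first", "only" and "open" are said of these compounds alone.

Compound 1 `CCN1CCN(c2cc(C)c3cc(NC(=O)c4cccc(Cl)c4)ccc3n2)CC1`: 17800 nM
Compound 2 `CCN1CCN(c2cc(C)c3cc(NC(=O)c4cccc(Br)c4)ccc3n2)CC1`: 13300 nM
Compound 3 `CCN1CCN(c2cc(C)c3cc(NC(=O)c4ccccc4Cl)ccc3n2)CC1`: a limit, > 50000 nM

In a functional assay on SK-BR-3 cells (Homo sapiens) for antiproliferative activity, read by MTT assay, with a stated time of 72 h (on this read-out lower numbers stand for stronger inhibition and higher numbers for weaker inhibition), compound 3 reaches only a limit, (the limit of > 50000 nM in this assay, at which 1 of the 3 values shown sits). Compound 1 and compound 2 both give measured numbers, and the two steps that lead to compound 3, an at least 2.8-fold higher number from compound 1 to compound 3 (0.44 log units; beyond the scatter) and an at least 3.7-fold higher number from compound 2 to compound 3 (0.57 log units; beyond the scatter), are each beyond the scatter. Compound 4 `CCN1CCN(c2cc(C)c3cc(NC(=O)c4ccc(C)cc4)ccc3n2)CC1` has not been measured. The change is 4-methylphenyl in place of 2-chlorophenyl on a carbonyl carbon. Among the measured compounds shown here, no measured step tests a 4-methylphenyl, so the expectation rests only on compound 3 sitting at the limit while compound 1 and compound 2 do not. Compound 4 is expected to give 25000 nM, between 9000 nM and 70000 nM, an estimated at least 2.0-fold lower number from compound 3 to compound 4 (0.30 log units; that floor lies within the scatter).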

Compound 4, half-maximal inhibitory concentration: 11400 nM
For compound 4 the middle estimate is 2.2-fold (0.34 log units) above the measured one; the measured number falls inside the stated range.
By their numbers in this assay, from the lowest: compounds 4, 2 and 1 (each within the scatter of the next). At a limit, above all of these: compound 3.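

On the carbonyl carbon, 4-methylphenyl in place of 2-chlorophenyl gives an at least 4.3-fold lower number from compound 3 to compound 4 (0.64 log units; beyond the scatter) in this assay, so an aryl amide without a halogen also comes off the limit. Compound 4 sits level with the 3-bromophenyl and 3-chlorophenyl amides, with a 1.2-fold lower number from compound 2 to compound 4 (0.07 log units; within the scatter) and a 1.6-fold lower number from compound 1 to compound 4 (0.19 log units; within the scatter). Compound 3 alone remains a limit: the limit of > 50000 nM in this assay, at which 1 of the 4 values shown sits.

Open, as far as these compounds go, is whether 2-methylphenyl would behave like 2-chlorophenyl, and whether 4-chlorophenyl would match 4-methylphenyl. Also open, from the compounds shown here alone, is what an amine or a carboxylic acid on this ring would do.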